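Removing the methyl from the hydroxymethyl-bearing amine substituent

The compounds below may be only part of what the source reports. "The series", "measured", "known", "first", "only" and "open" are said of these compounds alone.

The series shares one core and differs in the group on the amine nitrogen of the aromatic ring. Compound 1 `C#CCNc1nc(N)nc2c1ncn2[C@H]1C[C@H](N=[N+]=[N-])[C@@H](CO)O1` carries propargyl there; in an ADME assay on PBMC cells (Homo sapiens) for cytotoxicity, with a stated time of 5 days (a lower number here means a stronger inhibitor, a higher number a weaker inhibitor), compound 1 gives > 100000 nM, which is a limit of the assay and not a number. Compound 2 `CC(C)(CO)Nc1nc(N)nc2c1ncn2[C@H]1C[C@H](N=[N+]=[N-])[C@@H](CO)O1` carries 1-(hydroxymethyl)-1-methylethyl in its place. In this assay compound 2 gives > 100000 nM, again only a limit. The step that the two limits leave unreadable from compound 1 to compound 2 therefore cannot be read. Among the measured compounds shown here, compound 3 `[N-]=[N+]=N[C@H]1C[C@H](n2cnc3c(NC4CC4)nc(Cl)nc32)O[C@@H]1CO` is the only member with a number: in this assay compound 3 gives 35300 nM. For the measured compounds named here, no single-change step links compound 3 to compound 2, so its value stands on its own. Compound 2 thus sits at the limit of > 100000 nM in this assay, at which 2 of the 3 values shown sit.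

Compound 4 `CC(CO)Nc1nc(N)nc2c1ncn2[C@H]1C[C@H](N=[N+]=[N-])[C@@H](CO)O1` is compound 2 with one change: hydrogen in place of methyl on a saturated chain carbon bound to a nitrogen on an aromatic ring and two saturated chain carbons. Going by the values given here, no measured step reports this change, and the one measured step is unreadable. With the reference point itself only a limit, the steps give no direction; the expectation is that compound 4 stays at the limit as well. Expected, then, is a step that the limit leaves unreadable from compound 2 to compound 4. Compound 4 is accordingly estimated at 150000 nM, within 50000 nM to 500000 nM, most likely reported only as a limit.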

Compound 4, half-maximal inhibitory concentration: > 100000 nM
Compound 4 ended at the assay's limit; the forecaster's own chance of this, stated with the estimate: 80%; the middle value lies beyond the limit too.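

In this assay compound 4 gives > 100000 nM, which is a limit and not a number, so the steps among compound 1, compound 2 and compound 4 cannot be read. Compound 4 therefore stands here: the limit of > 100000 nM in this assay, at which 3 of the 4 values shown sit.

The compounds shown leave open whether the amine substituent changes the result in this assay for compound 1, compound 2 and compound 4.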